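From compound 2 to compound 4: an aryl ring exchange

A few compounds are considered here, and "the series" means these few. Any claim that something is new, unique, unknown or untested is made for them only; others in the source may bear on it.

Compound 1, `NC(=O)CNCc1ccc(OCc2cccc(F)c2)cc1`: 2240 nM in an assay on mitochondria for inhibition of Amine oxidase [flavin-containing] B (Rattus norvegicus); a higher number here means a weaker inhibitor, a lower number a stronger inhibitor
Compound 2, `NC(=O)[C@H](CO)NCc1ccc(OCc2ccc(Cl)cc2)cc1`: 1100 nM in this assay
Compound 3, `NC(=O)[C@@H](NCc1ccc(OCc2ccccc2)cc1)c1ccccc1`: 73800 nM in this assay

Among these three, compound 2 gives the lowest number in this assay. Compound 1 lies nearest to it, with a higher number that is beyond the scatter, and compound 3 lies furthest, with a much higher number. Compound 4, `NC(=O)[C@H](CO)NCc1ccc(OCc2cccc(F)c2)cc1`, has not yet been measured. It differs from compound 2 by 3-fluorophenyl in place of 4-chlorophenyl on a saturated chain carbon bound to an oxygen on an aromatic ring. For the measured compounds named here, no measured pair shows this exchange on its own; compounds 1 and 2 differ in this ring but also elsewhere, so their two values show only that the combined change moves the number by a modest amount. The step from compound 2 to compound 4 is therefore expected to be small, a 1.4-fold higher number from compound 2 to compound 4 (0.13 log units; within the scatter), toward a slightly higher number and possibly not beyond the scatter. Compound 4 is estimated at 1500 nM, with a range from 500 nM to 5000 nM.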

Compound 4, half-maximal inhibitory concentration: 140 nM
Compound 4: middle estimate off by 11-fold (1.03 log units), on the high side; the measured number lies below the stated range.
By their numbers in this assay, from the lowest: compound 4; then compound 2; then compound 1; then compound 3.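

With the serine-type side chain held constant, the ring exchange can now be read on its own in this assay: 3-fluorophenyl in place of 4-chlorophenyl gives a step beyond the scatter (a 7.9-fold lower number from compound 2 to compound 4 (0.90 log units; beyond the scatter)), so this position is sensitive to the choice of aryl ring. For the compounds shown here, with the 3-fluorophenyl ring held constant, hydroxymethyl in place of hydrogen on a saturated chain carbon bound to an amine nitrogen and a carbonyl carbon can also be read alone (a 16-fold lower number from compound 1 to compound 4 (1.20 log units; beyond the scatter)), a contribution that the combined difference between the earlier compounds had concealed. Nothing at hand accounts for either step.

From the compounds shown here alone, what a 3-chlorophenyl or 4-fluorophenyl ring would give on the same core remains open, so the halogen and its ring position cannot yet be told apart. Also open, going by these compounds, is how an aminomethyl group or a longer chain would read in place of the hydroxymethyl.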